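Removing a Methoxy Group: Will Low Toxicity Hold?

A few compounds are considered here, and "the series" means these few. Any claim that something is new, unique, unknown or untested is made for them only; others in the source may bear on it.

In an ADME assay on HeLa cells (Homo sapiens) for cytotoxicity, read by MTT assay (on this read-out higher numbers stand for lower toxicity in this test and lower numbers for higher toxicity in this test), compound 1 `Cc1nc(-c2cccnc2)sc1-c1nnc(-c2cccnc2)o1` gives > 100 ug/mL, which is a limit of the assay rather than a number. In this assay compound 2 `Cc1ccc(-c2nnc(-c3sc(-c4cccnc4)nc3C)o2)cc1` gives > 100 ug/mL, again a limit. In this assay compound 3 `COc1ccccc1-c1nnc(-c2sc(-c3cccnc3)nc2C)o1` gives > 100 ug/mL, also a limit. Compound 3 thus stands at the ceiling of what the test reports, and it shares that position with both other compounds, as the limit of > 100 ug/mL in this assay, at which 3 of the 3 values shown sit, shows. The three measured steps a step that the two limits leave unreadable from compound 1 to compound 2, a step that the two limits leave unreadable from compound 1 to compound 3 and a step that the two limits leave unreadable from compound 2 to compound 3 cannot be read in size or direction because the limit of > 100 ug/mL in this assay, at which 3 of the 3 values shown sit, puts every value at the same limit.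

Compound 4 `Cc1nc(-c2cccnc2)sc1-c1nnc(-c2ccccc2)o1` differs from compound 3 by hydrogen in place of methoxy on an aromatic carbon. For the measured compounds named here, no measured step gives a readable size, so nothing here points to a change beyond the scatter in this assay. The step from compound 3 to compound 4 is therefore expected to be a step that the limit leaves unreadable from compound 3 to compound 4. Compound 4 is expected to give 150 ug/mL in this assay, within a range from 60 ug/mL to 400 ug/mL, most likely again reported only as a limit.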

Compound 4, half-maximal cytotoxic concentration: > 100 ug/mL
Compound 4 gave a limit, no number; the forecaster's own chance of this, stated with the estimate: 85%; the middle value is on the limit's open side.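

Compound 4 joins compound 1, compound 2 and compound 3 at the same limit in this assay, so no step among them can be read in size or direction: the limit of > 100 ug/mL in this assay, at which 4 of the 4 values shown sit.

The compounds shown leave open whether any of these group changes alters toxicity in this test, since none of the four gives an actual number.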